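A few compounds are considered here, and "the series" means these few. Any claim that something is new, unique, unknown or untested is made for them only; others in the source may bear on it.

Measured so far:
compound 1 `Brc1ccc(OC[C@@H]2CCN2)cn1` — 0.021 nM
compound 2 `Fc1cncc(OC[C@@H]2CCN2)c1` — 0.076 nM

Both values come from an assay on brain for binding affinity to Neuronal acetylcholine receptor; alpha4/beta2 (Rattus norvegicus), read by radioligand binding; a higher number here means a weaker inhibitor, a lower number a stronger inhibitor. Compound 2 stands at the higher of the two numbers; compound 1 lies at a lower number, a gap beyond the scatter. Compound 3 `NCc1cncc(OC[C@@H]2CCN2)c1` is not yet measured. It differs from compound 2 by aminomethyl in place of fluoro on an aromatic carbon. Within the data shown here, no step of this kind between measured compounds is known, so the direction rests on expectation alone: a modest rise in the number, roughly at the edge of the scatter, is expected rather than a large shift. For compound 3 the estimate in this assay is 0.15 nM, with a range of 0.03 nM to 1 nM. The expected step of a 2.0-fold higher number from compound 2 to compound 3 (0.30 log units; within the scatter) is small and upward.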

Compound 3, inhibition constant: 4.4 nM
Beside the measured number, compound 3's estimate is 29-fold (1.47 log units) below it; measured number outside the range, above it.
By their numbers in this assay, from the lowest: compound 1; then compound 2; then compound 3.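

In this assay, aminomethyl in place of fluoro on this aromatic carbon, two atoms from the ring nitrogen, gives a 58-fold higher number from compound 2 to compound 3 (1.76 log units; beyond the scatter). This position is therefore sensitive to the group it carries, and this single change moves the number well beyond the scatter. As far as these compounds go, whether a methyl, a hydroxymethyl or an aminoethyl chain here would land nearer compound 2 or compound 3 stays open, so the step cannot yet be divided between the added carbon and the amine. Nothing available bears on the cause of this step.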